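From Cyclopropyl to Cyclopropylmethyl on a Shared Core

The source may hold more compounds than are shown below. What is called first, only, known or untested is meant among the compounds shown, and "the series" means these compounds.

In a physicochemical assay for solubility, using the shake flask method, in phosphate buffer, measured as kinetic solubility, with a stated time of 20 h, at pH 6.5 (on this read-out higher numbers stand for higher solubility and lower numbers for lower solubility), compound 1, `FC(F)(F)c1ccc(Nc2cc3[nH]c(C4CCOC4)nc3cn2)nc1`, gives 166000 nM. Compound 2, `FC(F)(F)c1ccc(Nc2cc3[nH]c(C4CC4)nc3cn2)nc1`, gives < 5000 nM, which is a limit of the assay and not a number. Going by these compounds, compound 2 therefore stands at the limit of < 5000 nM in this assay, at which 1 of the 2 values shown sits, and its true position on the scale remains unknown.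

The next structure is compound 3, `FC(F)(F)c1ccc(Nc2cc3[nH]c(CC4CC4)nc3cn2)nc1`, which carries cyclopropylmethyl in place of cyclopropyl on an aromatic carbon.

Among the measured compounds shown here, only one measured step is available, an at least 33-fold lower number from compound 1 to compound 2 (1.52 log units; beyond the scatter), and it came with cyclopropyl in place of oxolan-3-yl on an aromatic carbon. That step bears only loosely on the new change, which involves no oxolan-3-yl and keeps the three-membered non-aromatic ring. On the strength of that single step, no change beyond the scatter is expected in this assay, and a second report of a limit is quite likely. The estimated step is a step that the limit leaves unreadable from compound 2 to compound 3. For compound 3 the estimate is 4000 nM, with an expected range of 1500 nM to 12000 nM.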

Compound 3, solubility: 118000 nM
Estimate against measurement, compound 3: 30-fold (1.47 log units) below, outside the stated range (above it).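

In this assay, the change from cyclopropyl with 3 heavy atoms to cyclopropylmethyl with 4 gives an at least 23-fold higher number from compound 2 to compound 3 (1.37 log units; beyond the scatter), so at this position, on an aromatic carbon between two ring nitrogen atoms, a small change that keeps the three-membered ring still moves the read-out by a large step. Oxolan-3-yl and cyclopropylmethyl, by contrast, are not told apart here, with a 1.4-fold lower number from compound 1 to compound 3 (0.15 log units; within the scatter), and compound 3, whose group is of carbon only, goes against any reading of the earlier pair as a divide between oxolan-3-yl and carbon-only groups. The size of the step from compound 2 remains a bound and not a measured distance because compound 2 sits at a limit: the limit of < 5000 nM in this assay, at which 1 of the 3 values shown sits.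

What the compounds shown leave open is whether the read-out stays at this level with a longer chain at the same place, such as cyclopropylethyl, or falls back as it does with cyclopropyl. They also leave open how a simple open chain such as isopropyl, or an amine on the same carbon, would compare on the shared core.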